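The source may hold more compounds than are shown below. What is called first, only, known or untested is meant among the compounds shown, and "the series" means these compounds.

Series notes, iodinated hydrazone set.

Measured in a functional assay on HepG2 cells (Homo sapiens) for cytotoxicity, with a stated time of 24 h; on this read-out higher numbers stand for weaker inhibition and lower numbers for stronger inhibition:
- compound 1 `O=C(N/N=C/c1cc(I)cc(I)c1O)c1ccc(O)cc1`: 19200 nM
- compound 2 `O=C(N/N=C/c1cc(I)cc(I)c1O)c1ccc(F)cc1`: 12100 nM
- compound 3 `CC(C)(C)c1ccc(C(=O)N/N=C/c2cc(I)c(O)c(I)c2)cc1`: 45900 nM

Compound 3 carries the highest of the three numbers in this assay; the nearest is compound 1 and the furthest is compound 2, both gaps beyond the scatter. Compound 4 `O=C(N/N=C/c1cc(I)c(O)c(I)c1)c1ccc(I)cc1` has not been measured. It differs from compound 3 in one place: iodo in place of tert-butyl on an aromatic carbon. Within the data shown here, the only step measured so far is a 1.6-fold lower number from compound 1 to compound 2 (0.20 log units; within the scatter); it concerns a hydroxy-to-fluoro exchange on an aromatic carbon of the benzoyl ring, not the tert-butyl that is replaced here, so it bears on the present step only loosely, as the one sign that a single exchange at that carbon moved the number within the scatter. Among the measured compounds shown here, no step of the tert-butyl-to-iodo kind has been measured. Compound 4 is accordingly expected to give a number close to that of compound 3 in this assay. The step of a 1.4-fold lower number from compound 3 to compound 4 (0.16 log units; within the scatter) is expected to stay within the scatter, with no direction claimed. The estimate for compound 4 in this assay is 32000 nM, between 12000 nM and 80000 nM.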

Compound 4, half-maximal inhibitory concentration: > 50000 nM
Compound 4: no number, only a limit (the forecaster's own chance of this, stated with the estimate: 10%); middle value at least 1.5-fold (0.19 log units) away from the limit.
By their numbers in this assay, from the lowest: compounds 2 and 1 (each within the scatter of the next); then compound 3. At a limit, above all of these: compound 4.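

In this assay compound 4 gives > 50000 nM, which is a limit of the assay and not a number. Iodo in place of tert-butyl on an aromatic carbon, para to a large group, gives an at least 1.0-fold higher number from compound 3 to compound 4 (0.03 log units; that floor lies within the scatter), so this change at this position brings no lower number, a point the hydroxy-to-fluoro step could not settle because no tert-butyl was involved there. Compound 4 is the one member of the series read only at a limit, so the true size of this step stays hidden: the limit of > 50000 nM in this assay, at which 1 of the 4 values shown sits.

From the compounds shown here alone, whether the step reaches beyond the scatter remains open. Also open, going by these compounds, is what an amine, a carboxylic acid or a longer chain at this carbon would do to the number in this assay.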